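A few compounds are considered here, and "the series" means these few. Any claim that something is new, unique, unknown or untested is made for them only; others in the source may bear on it.

Measured in a functional assay (trachea) with Cavia porcellus as the target; on this read-out lower numbers stand for an effect already at smaller amounts and higher numbers for an effect only at larger amounts of compound:

- compound 1 `CCCn1c(=O)n(CCCO)c(=O)c2[nH]cnc21`: 5100 nM
- compound 2 `CCCn1cnc2c1c(=O)n(C)c(=O)n2CCC`: 5000 nM

For the measured compounds named here, only two compounds have been measured so far, so there is little to rank. Compound 2 gives 5000 nM and compound 1 gives 5100 nM. Going by the values given here, these two values agree within the usual scatter, so compound 2 sits level with the only other measured compound.

The next compound is compound 3 `CCCn1c(=O)n(C)c(=O)c2c1ncn2CCO`, which is not yet measured in this assay. It comes from compound 2 by one change: hydroxy in place of methyl on a saturated chain carbon, two bonds along the chain from an aromatic nitrogen. Put another way, a propyl chain becomes 2-hydroxyethyl.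

Among the compounds with values here, no measured pair shows this change on its own, so any expectation rests on thin evidence. Compound 1 also carries a hydroxy group on a chain and gives 5100 nM, but it differs from compound 2 in more than one place. A modest move towards a higher number therefore seems more likely than a large one. The expected change is a 2.4-fold higher number from compound 2 to compound 3 (0.38 log units; beyond the scatter). For compound 3 the estimated value is 12000 nM, with an expected range from 4000 nM to 40000 nM.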

Compound 3, half-maximal effective concentration: 31800 nM
The estimate for compound 3 lay 2.7-fold (0.42 log units) below the measured number; the range from low to high includes it.
By their numbers in this assay, from the lowest: compounds 2 and 1 (each within the scatter of the next); then compound 3.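

In this assay, for the compounds shown here, the change of a propyl chain to 2-hydroxyethyl, hydroxy in place of methyl on a saturated chain carbon, goes with a 6.4-fold higher number from compound 2 to compound 3 (0.80 log units; beyond the scatter) and is the first step that shows one change on its own. The earlier compounds shown here could not show this, since compound 1 and compound 2 differ in more than one place. The read-out at this position is therefore not indifferent to the group there: exchanging one carbon for one oxygen, which adds one hydrogen-bond donor and one hydrogen-bond acceptor, moves the number beyond the scatter, though nothing measured here speaks to the reason for the shift.

One step cannot tell whether the rise belongs to the hydroxy group itself or would also come with a methoxy group, an amine or a carboxylic acid in its place. It also leaves open whether a longer chain ending in hydroxy would give a smaller or a larger step, or whether any chain with hydroxy would lead to a lower number.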